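Trading an aromatic ring for cyclohexyl in the side chain

The source may report more compounds than this note shows. Statements on the series, on what has been measured and on what is new or still open speak of the compounds shown alone.

The series shares one core, varied only in the group on a saturated chain carbon bound to an aromatic nitrogen. Compound 1 `C[C@H](NC(=O)c1c(-c2ccccc2)nnn1Cc1ccccc1)c1ccc(C(=O)O)cc1` gives 647 nM in a functional assay on CHO cells for antagonist activity at prostaglandin E2 receptor EP4 subtype (Homo sapiens), read by calcium flux, with a stated time of 15 min; on this read-out lower numbers stand for stronger inhibition and higher numbers for weaker inhibition. Compound 2 `C[C@H](NC(=O)c1c(-c2ccccc2)nnn1Cc1ccc(F)c(F)c1)c1ccc(C(=O)O)cc1` gives 148 nM, a step of a 4.4-fold lower number from compound 1 to compound 2 (0.64 log units; beyond the scatter). Compound 3 `COc1ccc(Cn2nnc(-c3ccccc3)c2C(=O)N[C@@H](C)c2ccc(C(=O)O)cc2)cc1F` gives 29.8 nM in this assay and stands lowest of the three: its nearest neighbour is compound 2, separated by a 5.0-fold lower number from compound 2 to compound 3 (0.70 log units; beyond the scatter), and the furthest is compound 1, separated by a 22-fold lower number from compound 1 to compound 3 (1.34 log units; beyond the scatter).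

Compound 4 `C[C@H](NC(=O)c1c(-c2ccccc2)nnn1CC1CCCCC1)c1ccc(C(=O)O)cc1` is not yet measured. The change from compound 3 is cyclohexyl in place of 3-fluoro-4-methoxyphenyl on a saturated chain carbon bound to an aromatic nitrogen. Among the measured compounds shown here, no measured step removes the aromatic ring itself; the three measured steps only show that the groups carried on that ring moved the number strongly, as the steps from compound 1 to compound 2 and from compound 2 to compound 3 above indicate. Compound 4 is therefore expected to lose most of what compound 3 gained, with an estimated step of an 8.4-fold higher number from compound 3 to compound 4 (0.92 log units; beyond the scatter). The estimate for compound 4 in this assay is 250 nM, within 50 nM to 1200 nM.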

Compound 4, half-maximal inhibitory concentration: > 10000 nM
Compound 4: no number, only a limit (the forecaster's own chance of this, stated with the estimate: 5%); at least 40-fold (1.60 log units) between middle value and limit.
By their numbers in this assay, from the lowest: compound 3; then compound 2; then compound 1. At a limit, above all of these: compound 4.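

Compound 4 gives no number in this assay, only a limit: the limit of > 10000 nM in this assay, at which 1 of the 4 values shown sits. Cyclohexyl in place of each aromatic group gives an at least 330-fold higher number from compound 3 to compound 4 (2.52 log units; beyond the scatter), an at least 67-fold higher number from compound 2 to compound 4 (1.82 log units; beyond the scatter) and, even from plain phenyl, an at least 15-fold higher number from compound 1 to compound 4 (1.18 log units; beyond the scatter). The earlier compounds showed only that groups carried on the aromatic ring moved the number, whereas this change shows that among these compounds the aromatic ring itself matters at this position, with even the unsubstituted phenyl of compound 1 staying clear of the limit.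

The limit leaves the true size of the loss unknown, so these steps give only its smallest extent. The compounds shown also leave open whether a methoxy group on the cyclohexyl ring would recover any of the loss, and whether a pyridine ring could stand in for the phenyl ring.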